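A few compounds are considered here, and "the series" means these few. Any claim that something is new, unique, unknown or untested is made for them only; others in the source may bear on it.

Working notes on the series built on the core of compound 1 `CCCC[C@@H](O)C(=O)N1N=CC[C@H]1C(=O)NCc1cc(Cl)ccc1-n1cnnn1`. Compound 2 `CC(C)(C)[C@@H](O)C(=O)N1OCC[C@H]1C(=O)NCc1cc(Cl)ccc1-n1cnnn1` and compound 3 `O=C(NCc1cc(Cl)ccc1-n1cnnn1)[C@@H]1C[C@H]2C[C@H]2N1C(=O)[C@H](O)c1cccc(F)c1` keep the same amide-linked aryl portion with different acyl and ring parts. Compound 4 `CC(C)CC[C@@H](O)C(=O)N1N=CC[C@H]1C(=O)NCc1cc(Cl)ccc1-n1cnnn1` has not yet been measured.

In an ADME assay on liver for metabolic stability, with Liver microsome (Homo sapiens) as the target, read by LC-MS, using microsomes (a higher number here means faster removal of the compound, a lower number slower removal), compound 1 gives < 12 mL.min-1.g-1, which is a limit of the assay and not a number. Compound 2 also returns a limit in this assay, < 12 mL.min-1.g-1. Among the compounds with values here, compound 3 is the only one with a measured number in this assay, 32 mL.min-1.g-1. Compound 1 therefore stands among the two of three values that sit at the limit of < 12 mL.min-1.g-1 in this assay, at which 2 of the 3 values shown sit, and nothing finer than that can be said of its position.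

Compound 4 differs from compound 1 by methyl in place of hydrogen on a saturated chain carbon bound to two saturated chain carbons. Within the data shown here, no step between measured compounds is available to calibrate this change, and the two compounds sharing the same acyl chain pattern give no numeric handle. The expected step in this assay, a step that the limit leaves unreadable from compound 1 to compound 4, is estimated to be none beyond the scatter, with compound 4 expected to remain at the limit as compound 1 does with < 12 mL.min-1.g-1. Compound 4 is thus estimated at 10 mL.min-1.g-1 in this assay, within 5 mL.min-1.g-1 to 22 mL.min-1.g-1, most likely again reported only as a limit.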

Compound 4, intrinsic clearance in microsomes: 47 mL.min-1.g-1
For compound 4 the middle estimate is 4.7-fold (0.67 log units) below the measured one, outside the stated range (above it).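

In this assay, the chain of the shared core proves sensitive to a very small change: methyl in place of hydrogen on a saturated chain carbon bound to two saturated chain carbons, which turns butyl into isopentyl, gives an at least 3.9-fold higher number from compound 1 to compound 4 (0.59 log units; beyond the scatter). The earlier compounds shown here offered no pair differing in one place, and neither the limit for compound 1 nor the limit for compound 2 could show that this position affects the read-out. The step is a lower bound and not an exact size, as the value for compound 1 is a limit of the assay: the limit of < 12 mL.min-1.g-1 in this assay, at which 2 of the 4 values shown sit.

As far as these compounds go, it remains open whether the step belongs to the branching itself or simply to the added carbon, and a straight pentyl chain on the shared core would separate the two. Also open, from the compounds shown here alone, is whether a hydroxyl group or a fluorine in place of the added methyl would bring the read-out back to the limit seen for compound 1, and whether the same change gives a similar step on the acyl and ring parts of compound 2 and compound 3.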